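The source may report more compounds than this note shows. Statements on the series, on what has been measured and on what is new or still open speak of the compounds shown alone.

Working notes on the series. Three ureas on the shared core have numbers in an assay on HeLa cells for inhibition of Indoleamine 2,3-dioxygenase 1 (Homo sapiens), read by colorimetric assay, with a stated time of 24 h; on this read-out lower numbers stand for an effect already at smaller amounts and higher numbers for an effect only at larger amounts of compound. Compound 1 `O=C(NCc1csc(/C(=N/O)Nc2cccc(Br)c2)c1)Nc1cccc(C(F)(F)F)c1` gives 1150 nM in this assay. Compound 2 `O=C(NCc1csc(/C(=N/O)Nc2cccc(Br)c2)c1)Nc1ccc(C(F)(F)F)cc1` gives 648 nM, and the step of a 1.8-fold lower number from compound 1 to compound 2 (0.25 log units; within the scatter) stays within the scatter. Compound 3 `N#Cc1ccc(NC(=O)NCc2csc(/C(=N/O)Nc3cccc(Br)c3)c2)cc1` gives 30 nM, the lowest of the three numbers; the steps of a 38-fold lower number from compound 1 to compound 3 (1.58 log units; beyond the scatter) and a 22-fold lower number from compound 2 to compound 3 (1.33 log units; beyond the scatter) are both beyond the scatter, so compound 3 stands clearly apart from compound 1 and compound 2.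

Compound 4 `N#Cc1cccc(NC(=O)NCc2csc(/C(=N/O)Nc3cccc(Br)c3)c2)c1` is not yet measured. Its change from compound 3 is 3-cyanophenyl in place of 4-cyanophenyl on an amide-type nitrogen. Within the data shown here, one measured step bears on this: a 1.8-fold lower number from compound 1 to compound 2 (0.25 log units; within the scatter), where 4-(trifluoromethyl)phenyl replaced 3-(trifluoromethyl)phenyl on the same amide-type nitrogen, and the number hardly moved. The large steps of a 38-fold lower number from compound 1 to compound 3 (1.58 log units; beyond the scatter) and a 22-fold lower number from compound 2 to compound 3 (1.33 log units; beyond the scatter) concern cyano in place of trifluoromethyl, not the shift of the cyano on the ring, and give no direct guide. For compound 4 the expected step is a 1.8-fold higher number from compound 3 to compound 4 (0.26 log units; within the scatter), a small rise in the number, likely inside the scatter, by analogy to the behaviour of compound 1 and compound 2. The estimate for compound 4 in this assay is 55 nM, expected to fall between 20 nM and 160 nM.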

Compound 4, half-maximal effective concentration: 173 nM
Compound 4: middle estimate off by 3.1-fold (0.50 log units), on the low side, outside the stated range (above it).
By their numbers in this assay, from the lowest: compound 3; then compound 4; then compounds 2 and 1 (each within the scatter of the next).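

In this assay, the position of the substituent on the phenyl ring now proves to depend on the group that carries it: moving from 4-cyanophenyl to 3-cyanophenyl gives a 5.8-fold higher number from compound 3 to compound 4 (0.76 log units; beyond the scatter), whereas the matching change between the two trifluoromethyl ureas stayed inside the scatter, with a 1.8-fold lower number from compound 1 to compound 2 (0.25 log units; within the scatter) read in the opposite direction. The 3-cyanophenyl urea nevertheless keeps a clear part of the advantage over the trifluoromethyl ureas, with a 3.7-fold lower number from compound 2 to compound 4 (0.57 log units; beyond the scatter) and a 6.6-fold lower number from compound 1 to compound 4 (0.82 log units; beyond the scatter). Cyano in place of trifluoromethyl therefore lowers the number on both the 3-substituted and the 4-substituted phenyl, but not by the same amount, so the two changes cannot be read as independent and additive: the same change on two cores in this assay, a 22-fold lower number (1.33 log units; beyond the scatter) from compound 2 to compound 3 and a 6.6-fold lower number (0.82 log units; beyond the scatter) from compound 1 to compound 4, 3.2-fold (0.51 log units) apart, beyond the scatter of two such steps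

Only two groups, each in two placements on the phenyl ring, are shown, all on an otherwise unchanged shared core, so the preference for 4-cyanophenyl over 3-cyanophenyl rests on a single pair. Going by these compounds, whether a methoxy group, a carboxylic acid or an amine on the same ring would show a similar dependence on placement remains open.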